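A few compounds are considered here, and "the series" means these few. Any claim that something is new, unique, unknown or untested is made for them only; others in the source may bear on it.

Measured so far:
- compound 1 `O=C(Nc1cccc(-n2cc(-c3ccncc3)c(-c3cc(O)cc(Cl)c3)n2)c1)Nc1ccc(Cl)c(Cl)c1`: 92%
- compound 2 `COc1cc(Cl)cc(-c2nn(-c3cccc(NC(=O)Nc4ccc(Cl)c(C(F)(F)F)c4)c3)cc2-c2ccncc2)c1`: 96%
- compound 3 `COc1cc(Cl)cc(-c2nn(-c3cccc(NC(=O)Nc4cc(C(F)(F)F)cc(C(F)(F)F)c4)c3)cc2-c2ccncc2)c1`: 96%

In a functional assay on 786-0 cells (Homo sapiens) for inhibition, read by sulforhodamine B assay, with a stated time of 48 h, tested at 0.01 uM (on this read-out higher numbers stand for a weaker effect at the one concentration tested and lower numbers for a stronger effect), compound 3 gives 96%, level with compound 2 at 96%, the two together standing at the top of the three numbers. Compound 1, at 92%, lies nearest to it among the rest, and the gap is within the scatter. Compound 4 `COc1cc(Cl)cc(-c2nn(-c3cccc(NC(=O)Nc4cccc(C(F)(F)F)c4)c3)cc2-c2ccncc2)c1` has not yet been measured in this assay. It differs from compound 3 in one place: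

hydrogen in place of trifluoromethyl on an aromatic carbon

Going by the values given here, no step between two measured compounds is known here. With all three numbers within the scatter of each other, the account expects the step of a number 2 percentage points lower from compound 3 to compound 4 (within the scatter) to show no change beyond the scatter. Compound 4 is therefore estimated at 94%, between 84% and 100%.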

Compound 4, a percentage reported as activity, at one concentration (the size of the read-out at that concentration, not a potency): 99%
Compound 4: the middle estimate sits 5 percentage points below what was measured; the measured number falls inside the stated range.
By their numbers in this assay, from the lowest: compounds 1, 2, 3 and 4 (each within the scatter of the next).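

In this assay, hydrogen in place of trifluoromethyl gives a number 3 percentage points higher from compound 3 to compound 4 (within the scatter), and hydrogen in place of chloro, on a different aromatic carbon, gives a number 3 percentage points higher from compound 2 to compound 4 (within the scatter). Going by these compounds alone, these are the first single-place steps, and they show that at this one concentration neither group on its carbon can be told from hydrogen. Nothing available bears on the reason for this. On these data alone, whether an amine or a carboxylic acid on these carbons would give a step beyond the scatter remains open.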